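Working notes: aryl substituent change from compound 2 to compound 4

The source may hold more compounds than are shown below. What is called first, only, known or untested is meant among the compounds shown, and "the series" means these compounds.

Values in a functional assay on L1210 cells (Mus musculus) for cytotoxicity, read by MTT assay, with a stated time of 48 h (on this read-out lower numbers stand for stronger inhibition and higher numbers for weaker inhibition), for the measured members:
- compound 1 `C=C1C(=O)OC(C)CC1c1ccc(Br)cc1` gives 1750 nM
- compound 2 `C=C1C(=O)O[C@H](C)[C@@H]1c1ccc(Br)cc1` gives 7800 nM
- compound 3 `C=C1C(=O)O[C@@H](C)[C@@H]1c1ccc(Br)cc1` gives 580 nM

Compound 2 gives the highest number of the three in this assay; compound 1 is nearest and compound 3 furthest. For the measured compounds named here, the one single-point step measured, a 13-fold lower number from compound 2 to compound 3 (1.13 log units; beyond the scatter), rests on the fact that compounds 2 and 3 differ only in the configuration as drawn and concerns configuration only. Compound 4 `C=C1C(=O)O[C@H](C)[C@@H]1c1ccc(C)cc1` differs from compound 2 by methyl in place of bromo on an aromatic carbon. Going by the values given here, no measured step touches a change at the aromatic ring, so nothing here sets a direction for it. Compound 4 is therefore expected to stay close to compound 2, with the estimated step of a 1.2-fold higher number from compound 2 to compound 4 (0.06 log units; within the scatter) within the scatter. For compound 4 the estimate in this assay is 9000 nM (range 3000 nM to 27000 nM).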

Compound 4, half-maximal inhibitory concentration: 5500 nM
Compound 4: the middle estimate sits 1.6-fold (0.21 log units) above what was measured, and the stated range covers the measured number.
By their numbers in this assay, from the lowest: compound 3; then compound 1; then compounds 4 and 2 (each within the scatter of the next).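

In this assay, for the compounds shown here, methyl in place of bromo on an aromatic carbon gives a 1.4-fold lower number from compound 2 to compound 4 (0.15 log units; within the scatter), the first measured change at the aromatic ring. At this position, para to a group of 8 heavy atoms, bromo and methyl are not told apart in the configuration of compound 2, so bromine is not required for a number of this size. Nothing at hand gives a reason for this result.

From the compounds shown here alone, it remains open how methyl behaves in the configuration of compound 3. Going by these compounds, an amine, a carboxylic acid or a methoxy group at this position also remains open.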